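Carbamate series: cytotoxicity working notes before compound 4

A few compounds are considered here, and "the series" means these few. Any claim that something is new, unique, unknown or untested is made for them only; others in the source may bear on it.

Measured so far:
compound 1, `CCCOC(=O)Nc1ccc([Se]C#N)cc1`: 68800 nM
compound 2, `CCOC(=O)Nc1ccc([Se][Se]c2ccc(NC(=O)OCC)cc2)cc1`: 74300 nM
compound 3, `Cc1ccc(OC(=O)Nc2ccc([Se][Se]c3ccc(NC(=O)Oc4ccc(C)cc4)cc3)cc2)cc1`: 75600 nM

All three values come from a functional assay on CCRF-CEM cells (Homo sapiens) for cytotoxicity, read by MTT assay, with a stated time of 72 h; on this read-out higher numbers stand for lower toxicity in this test and lower numbers for higher toxicity in this test. Compound 1 carries the lowest number of the three, but compound 2 and compound 3 each differ from it by an amount within the usual scatter, so the three compounds cannot be separated on this read-out. Among the compounds with values here, no pair among them differs in a single place, so no step of known size is available.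

The next compound, compound 4, is `C=CCOC(=O)Nc1ccc([Se]C#N)cc1`. It differs from compound 1 by vinyl in place of ethyl on a saturated chain carbon bound to an oxygen next to a carbonyl group; cut one bond further out, the change reads propyl to allyl, or propoxy to allyloxy. The rest of compound 1 is kept.

With no measured step of this kind in the series, and the three measured compounds lying together within the scatter, the expectation for the change from compound 1 to compound 4 in this assay is no movement beyond the scatter, in either direction: the expected step is a 1.1-fold lower number from compound 1 to compound 4 (0.02 log units; within the scatter). For compound 4 the estimate in this assay is 65000 nM, with a range from 30000 nM to 140000 nM.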

Compound 4, concentration lethal to 50% of the cells: 68600 nM
Estimate against measurement, compound 4: 1.1-fold (0.02 log units) below, and the stated range covers the measured number.
By their numbers in this assay, from the lowest: compounds 4, 1, 2 and 3 (each within the scatter of the next).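

In this assay, within the data shown here, vinyl in place of ethyl on a saturated chain carbon bound to an oxygen next to a carbonyl group gives a 1.0-fold lower number from compound 1 to compound 4 (0.00 log units; within the scatter) and supplies the first single-place step. The same difference, read as propyl to allyl or propoxy to allyloxy, keeps the count of two heavy atoms in the exchanged group and adds one double bond outside aromatic rings, and on this read-out compound 4 cannot be separated from compound 1. No measurement at hand bears on why this change leaves the two compounds together.

One step at one place says nothing yet about how other groups behave here: a longer chain, a terminal amine or a carboxylic acid on this chain could still move the number beyond the scatter. Among these compounds, no single-place pair yet connects the selenium-bound nitrile of compound 1 and compound 4 with the diselenide form of compound 2 and compound 3, so the contribution of that part of the structure remains open.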